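The compounds below may be only part of what the source reports. "The series", "measured", "known", "first", "only" and "open" are said of these compounds alone.

Compound 3 `O=C1NC(c2ccccc2)C(=O)N1C1CCCC1` sits at the edge of what a functional assay on HeLa cells (Homo sapiens) for inhibition (a lower number here means a stronger inhibitor, a higher number a weaker inhibitor), can report: in this assay compound 3 gives > 100000 nM, which is a limit rather than a number. That is the limit of > 100000 nM in this assay, at which 1 of the 3 values shown sits. Compound 4 `CCC(C)C1NC(=O)N(C2CCCC2)C1=O` differs from it by sec-butyl in place of phenyl on a saturated ring carbon. The other measured compounds sit in the same region. Compound 1 `CCC(C)C(NC(=O)n1nnc2ccccc21)C(=O)NCc1ccccc1` gives >= 100000 nM in this assay, also a limit. Compound 2 `CCC(C)C(NC(=O)n1nnc2ccccc21)C(=O)NC1CCCC1` gives 82300 nM in this assay. Among the measured compounds shown here, the only measured step, an at least 1.2-fold lower number from compound 1 to compound 2 (0.08 log units; that floor lies within the scatter), alters a different group at a different place, so no measured step tests the exchange of phenyl for sec-butyl. No change beyond the scatter is expected. Compound 4 is estimated at 100000 nM, with a range from 30000 nM to 300000 nM. The expected step is a number no higher from compound 3 to compound 4 (the limit leaves the size open).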

Compound 4, half-maximal inhibitory concentration: > 100000 nM
Compound 4 was reported as a limit; the forecaster's own chance of this, stated with the estimate: 70%; the middle value lies on the limit itself.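

Among the compounds shown here, compound 3 and compound 4 are both reported only as limits in this assay, so no step between them can be read. The compounds shown leave open whether sec-butyl in place of phenyl changes inhibition at all.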